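Chloro placement on the phenyl arm of a thiazole series

The source may hold more compounds than are shown below. What is called first, only, known or untested is meant among the compounds shown, and "the series" means these compounds.

Compound 1 `Cc1nc(-c2ccc(Cl)cc2)sc1C(=O)CSc1nc(-c2ccccc2)c(C#N)c(=O)[nH]1` was tested in a functional assay on U-87MG ATCC cells for antiproliferative activity against U-87 MG (Homo sapiens), read by MTT assay, with a stated time of 48 h, tested at 50 uM (a higher number here means a weaker effect of the compound at the concentration tested, a lower number a stronger effect), where compound 1 gives 41.6%. Compound 2 `Cc1nc(-c2ccc(Cl)cc2)sc1C(=O)CSc1nc(-c2ccc(Cl)cc2)c(C#N)c(=O)[nH]1` differs from it by chloro in place of hydrogen on an aromatic carbon, and in this assay compound 2 gives 60%; the step is a number 18.4 percentage points higher from compound 1 to compound 2 (beyond the scatter). Compound 3 `COc1ccc(-c2nc(C)c(C(=O)CSc3nc(-c4ccccc4)c(C#N)c(=O)[nH]3)s2)cc1` carries a different core, the difference being (methoxy in place of chloro on an aromatic carbon), and in this assay compound 3 gives 72.5%; the step is a number 30.9 percentage points higher from compound 1 to compound 3 (beyond the scatter). Among the three measured compounds, compound 3 stands highest, with compound 2 the nearest and compound 1 the furthest.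

Compound 4 `COc1ccc(-c2nc(C)c(C(=O)CSc3nc(-c4cccc(Cl)c4)c(C#N)c(=O)[nH]3)s2)cc1` has not yet been measured. It differs from compound 3 by chloro in place of hydrogen on an aromatic carbon. Going by the values given here, this is the same kind of change as the one from compound 1 to compound 2, not the same change: in the earlier pair the chloro enters para to a large group, whereas in compound 4 it enters meta to a large group, and the core is the one of compound 3 rather than that of compound 1.

The expectation for compound 4 rests on one precedent. Because the step from compound 1 to compound 2 was a number 18.4 percentage points higher from compound 1 to compound 2 (beyond the scatter), an upward step is expected from compound 3 to compound 4 in this assay, estimated at a number 11.5 percentage points higher from compound 3 to compound 4 (beyond the scatter), though the different place of the chloro and the already high starting point of compound 3 make a smaller step plausible. Compound 4 is therefore estimated to give 84% in this assay, expected to fall between 70% and 98%.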

Compound 4, a percentage reported as activity, at one concentration (the size of the read-out at that concentration, not a potency): 83.4%
Estimate against measurement, compound 4: 0.6 percentage points above, within the range that was stated.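

On the core of compound 3, chloro in place of hydrogen on the phenyl arm again moves the read-out in the same direction in this assay: the step is a number 10.9 percentage points higher from compound 3 to compound 4 (beyond the scatter), which means a weaker effect at the concentration tested. Set beside the earlier step on the core of compound 1, the new step agrees in direction and cannot be told apart from it in size: the same change on two cores in this assay, a number 18.4 percentage points higher (beyond the scatter) from compound 1 to compound 2 and a number 10.9 percentage points higher (beyond the scatter) from compound 3 to compound 4, 7.5 percentage points apart, within the scatter of two such steps This shows that, in these two pairs, the weakening carried over from one core to the other, but two pairs are a narrow base, the chloro does not enter at the same place in both, and the core and the place of the chloro change together, so neither can be credited separately, and readings at a single concentration say nothing about potency.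

The compounds shown leave open whether phenyl to 3-chlorophenyl would give a similar step on the core of compound 1, and whether the same placement of chloro on both cores would give matching steps. They also leave open how this assay would respond to a fluoro, a methyl or an amine on that phenyl arm, or to a carboxylic acid in place of the nitrile.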